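The source may hold more compounds than are shown below. What is called first, only, known or untested is meant among the compounds shown, and "the series" means these compounds.

Working notes on the series.

The shared core carries a propyl-linked piperidine; the compounds differ in what sits on the piperidine. In an assay on CHO cells for displacement of a labelled ligand from 5-hydroxytryptamine receptor 1B (Homo sapiens) (a higher number here means a weaker inhibitor, a lower number a stronger inhibitor), compound 1 `CN(CC1CCN(CCCc2c[nH]c3ccc(-n4cnnc4)cc23)CC1)C(=O)Nc1ccccc1` gives 6.2 nM. Compound 2 `C[C@@H](NCC1CCN(CCCc2c[nH]c3ccc(-n4cnnc4)cc23)CC1)c1ccccc1` gives 14 nM in this assay, and compound 3 `OC[C@H](NC1CCN(CCCc2c[nH]c3ccc(-n4ccnc4)cc23)CC1)c1ccccc1`, which also differs from the others in the five-membered heteroaromatic ring on the core, gives 100 nM in this assay. Among the three numbers compound 2 therefore stands second highest: compound 1 sits a modest distance lower, compound 3 a larger distance higher.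

The next compound, compound 4 `CN(Cc1cccs1)C1CCN(CCCc2c[nH]c3ccc(-n4cnnc4)cc23)CC1`, is compound 2 with methyl((thiophen-2-yl)methyl)amino in place of ((1-phenylethyl)amino)methyl on a saturated ring carbon. For the measured compounds named here, the one measured step that bears on this terminal group is a 2.3-fold higher number from compound 1 to compound 2 (0.35 log units; beyond the scatter), which shows that reshaping the amine end of the side chain moves the number only modestly. Compounds 2 and 3 are not a single-place pair, so their gap is read only as two values: the direct ring-carbon amine with the hydroxymethyl group sits clearly higher. Going by the values given here, no measured step covers removing the amine hydrogen together with shortening the link and swapping the aromatic ring.

On this basis a modest upward step is expected, a 2.0-fold higher number from compound 2 to compound 4 (0.30 log units; within the scatter), and compound 4 is estimated at 28 nM, within 8 nM to 100 nM in this assay.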

Compound 4, half-maximal inhibitory concentration: 140 nM
For compound 4 the middle estimate is 5.0-fold (0.70 log units) below the measured one, outside the stated range (above it).
By their numbers in this assay, from the lowest: compound 1; then compound 2; then compounds 3 and 4 (each within the scatter of the next).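

In this assay, the change on this saturated ring carbon gives a 10-fold higher number from compound 2 to compound 4 (1.00 log units; beyond the scatter), a larger step than a 2.3-fold higher number from compound 1 to compound 2 (0.35 log units; beyond the scatter), so the number at this position does respond strongly to at least some changes of the terminal group. The exchange alters several features at once: the phenyl ring gives way to a thiophene, the hydrogen-bond donor and the defined stereocentre are lost, and the entering group has fewer heavy atoms than the group it replaces, so the step belongs to the whole exchange and not to any one of these features. No supporting measurement bears on what produces this step.

As far as these compounds go, it remains open whether the thiophene, the methyl on the amine, or the attachment of the amine directly to the ring carbon accounts for most of the step. A benzyl group in place of the thiophen-2-ylmethyl group, or an amine hydrogen in place of the methyl, with the rest of compound 4 unchanged, would separate these contributions.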